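The compounds below may be only part of what the source reports. "The series", "measured", "known", "first", "only" and "open" are said of these compounds alone.

Measured compounds:
- compound 1, `COc1cc(-c2nn(-c3cccc(NC(=O)c4cccc(C(F)(F)F)c4)c3)cc2-c2ccncc2)ccc1Cl`, gives 3000 nM
- compound 2, `O=C(Nc1cccc(-n2cc(-c3ccncc3)c(-c3ccc(Cl)c(O)c3)n2)c1)Nc1cc(C(F)(F)F)cc(C(F)(F)F)c1`, gives 1650 nM
- compound 3, `COc1cc(-c2nn(-c3cccc(NC(=O)Nc4ccc(Cl)c(C(F)(F)F)c4)c3)cc2-c2ccncc2)ccc1Cl`, gives 2540 nM

All three were tested in a functional assay on SF-295 cells (Homo sapiens) for inhibition, read by sulforhodamine B assay, with a stated time of 48 h; on this read-out lower numbers stand for stronger inhibition of growth and higher numbers for weaker inhibition of growth. Among the three numbers, compound 1 has the highest, but its neighbours sit close: the step of a 1.2-fold lower number from compound 1 to compound 3 (0.07 log units; within the scatter) is within the scatter, and the gap to compound 2 is within the scatter as well, so the three compounds cannot be told apart on these numbers.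

Compound 4, `COc1cc(-c2nn(-c3cccc(NC(=O)c4ccccc4)c3)cc2-c2ccncc2)ccc1Cl`, has not yet been measured. It differs from compound 1 in one place: hydrogen in place of trifluoromethyl on an aromatic carbon. Within the data shown here, the only measured step that changes the same end of the molecule is the one from compound 1 to compound 3, where the whole aryl attached to the carbonyl was exchanged and the number barely moved. Among the measured compounds shown here, no measured pair removes a trifluoromethyl while leaving the rest untouched, so there is no direct precedent. Given how little the one related step moved, a small change is expected, with the direction uncertain; compound 4 is estimated at 4000 nM, between 1500 nM and 11000 nM, a step of a 1.3-fold higher number from compound 1 to compound 4 (0.12 log units; within the scatter).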

Compound 4, concentration for total growth inhibition: 2260 nM
Compound 4: the middle estimate sits 1.8-fold (0.25 log units) above what was measured; low and high end bracket the measured number.
By their numbers in this assay, from the lowest: compounds 2, 4, 3 and 1 (each within the scatter of the next).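

In this assay the step of a 1.3-fold lower number from compound 1 to compound 4 (0.12 log units; within the scatter) lies within the scatter, so taking the trifluoromethyl off this aromatic carbon and leaving a plain hydrogen causes no change that these numbers can detect. Among these compounds, this is the first pair to alter that one group alone, since the earlier step from compound 1 exchanged the whole group on the carbonyl carbon. The step of a 1.1-fold lower number from compound 3 to compound 4 (0.05 log units; within the scatter) also lies within the scatter, so a bare phenyl on the carbonyl carbon cannot be told apart from the larger (4-chloro-3-(trifluoromethyl)phenyl)amino group, and at this end of the molecule neither the trifluoromethyl nor the extra bulk shows any measurable contribution; no other data bear on why this is so.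

Going by these compounds, only hydrogen and trifluoromethyl have been seen on this aromatic carbon, so it remains open whether an amine, a carboxylic acid or a longer chain there would also leave the number unmoved. On these data alone, with every compound here within the scatter of its neighbour, it also remains open which change at this end of the molecule, if any, would shift growth inhibition in this assay by more than the scatter.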